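Octyl in place of oct-1-yn-1-yl on compound 1

The compounds below may be only part of what the source reports. "The series", "measured", "known", "first", "only" and "open" are said of these compounds alone.

Within the data shown here, compound 1 `CCCCCCC#Cc1ccc(S(=O)(=O)Nc2cccc(-c3csc(NC(C)=O)n3)c2)cc1` gives 5.8% in a functional assay on A-375 cells (Homo sapiens) for antiproliferative activity, read by trypan blue exclusion, with a stated time of 48 h, tested at 10 uM (a lower number here means a stronger effect, a higher number a weaker effect of the compound at the concentration tested), the higher of the two numbers so far, with compound 2 `C#Cc1ccc(S(=O)(=O)Nc2cccc(-c3csc(NC(C)=O)n3)c2)cc1` at 1.2% lying within the scatter; the step of a number 4.6 percentage points lower from compound 1 to compound 2 (within the scatter) changes nothing of note. Compound 3 `CCCCCCCCc1ccc(S(=O)(=O)Nc2cccc(-c3csc(NC(C)=O)n3)c2)cc1` carries octyl in place of oct-1-yn-1-yl on an aromatic carbon. Among the measured compounds shown here, no measured step saturates the triple bond while keeping the chain; the only step known, hydrogen in place of hexyl on a triple-bonded carbon, stayed within the scatter. The expected step is therefore a number 0.2 percentage points higher from compound 1 to compound 3 (within the scatter), none beyond the scatter. Compound 3 is estimated at 6%, between 0% and 18%.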

Compound 3, a percentage reported as activity, at one concentration (the size of the read-out at that concentration, not a potency): < 1%
Compound 3 gave a limit, no number (the forecaster's own chance of this, stated with the estimate: 2%); middle value at least 5 percentage points from the limit.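

In this assay compound 3 gives < 1%, which is a limit of the assay and not a number: the limit of < 1% in this assay, at which 1 of the 3 values shown sits.

The steps read a number at least 4.8 percentage points lower from compound 1 to compound 3 (that floor lies within the scatter) and a number at least 0.2 percentage points lower from compound 2 to compound 3 (that floor lies within the scatter). On this aromatic carbon, then, a triple bond is not needed for the read-out to stay this low, as the octyl chain without one shows.

On these data alone, whether an amine or a carboxylic acid at the end of the octyl chain would keep the read-out this low stays open. Any ranking of the three compounds also stays open.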